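The source may hold more compounds than are shown below. What is called first, only, known or untested is meant among the compounds shown, and "the series" means these compounds.

Measured compounds:
- compound 1 `CN(Cc1ccc(-c2ccccc2-c2nn[nH]n2)cc1)C(=O)[C@@H](CCc1ccccc1)NC(=O)CCC(C)(C)N`; in a functional assay (Pituitary gland cell) with Rattus norvegicus as the target (on this read-out higher numbers stand for an effect only at larger amounts of compound and lower numbers for an effect already at smaller amounts), compound 1 reaches only a limit of the assay, > 0.3 uM.
- compound 2 `CN(Cc1ccc(-c2ccccc2-c2nn[nH]n2)cc1)C(=O)[C@@H](CCc1ccccc1)NC(=O)C(C)(C)N`; in this assay compound 2 gives 0.03 uM.

Among the compounds with values here, compound 2 thus holds the only numeric value in this assay; the other entry is a limit. The step of an at least 10-fold lower number from compound 1 to compound 2 (1.00 log units; beyond the scatter) is bounded because compound 1 sits at the limit of > 0.3 uM in this assay, at which 1 of the 2 values shown sits. Compound 3 `CN(Cc1ccc(-c2ccccc2-c2nn[nH]n2)cc1)C(=O)[C@@H](CCc1ccccc1)NC(=O)CC(C)(C)N` differs from compound 2 by 2-amino-2-methylpropyl in place of 1-amino-1-methylethyl on a carbonyl carbon, a chain intermediate in length between those of compound 1 and compound 2. Only an at least 10-fold lower number from compound 1 to compound 2 (1.00 log units; beyond the scatter) bears on it, and the shorter chain gave the lower number, so an intermediate chain is expected to land between the two. For compound 3 the estimate is 0.1 uM (range 0.03 uM to 0.5 uM). This corresponds to an expected step of a 3.3-fold higher number from compound 2 to compound 3 (0.52 log units; beyond the scatter).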

Compound 3, concentration for half-maximal effect: > 0.3 uM
Compound 3 ended at the assay's limit; the forecaster's own chance of this, stated with the estimate: 20%; middle value at least 3.0-fold (0.47 log units) from the limit.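

Lengthening 1-amino-1-methylethyl to 2-amino-2-methylpropyl on the carbonyl carbon already gives an at least 10-fold higher number from compound 2 to compound 3 (1.00 log units; beyond the scatter) in this assay, so the low number does not survive even the intermediate chain and, among the three chains, belongs to 1-amino-1-methylethyl alone. Compound 3 gives > 0.3 uM, which is a limit of the assay. Compound 1 also stands at a limit, and the step between these two compounds cannot be read: the limit of > 0.3 uM in this assay, at which 2 of the 3 values shown sit.

Open, on these data alone, is whether aminomethyl, 1-aminocyclopropyl or 1-aminoethyl on the same carbonyl carbon keeps the low number. Also open, as far as these compounds go, is whether the amine itself is needed, for instance against a hydroxyl or a carboxylic acid in its place.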